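Urea series: chloro replaces trifluoromethyl on the aryl amine

A few compounds are considered here, and "the series" means these few. Any claim that something is new, unique, unknown or untested is made for them only; others in the source may bear on it.

Two compounds of the series have numbers in a functional assay on LOX IMVI cells (Homo sapiens) for inhibition, read by sulforhodamine B assay, with a stated time of 48 h, tested at 10 uM; a higher number here means a weaker effect of the compound at the concentration tested, a lower number a stronger effect. Compound 1 `COc1cc(Cl)cc(-c2nn(-c3cccc(NC(=O)c4ccc(Cl)c(Cl)c4)c3)cc2-c2ccncc2)c1` gives 72.8% in this assay. Compound 2 `O=C(Nc1cccc(-n2cc(-c3ccncc3)c(-c3cc(O)cc(Cl)c3)n2)c1)Nc1ccc(Cl)c(C(F)(F)F)c1` gives 2.08% in this assay. Compound 2 stands lowest of the two numbers; the nearest number is that of compound 1, which lies higher by a margin beyond the scatter. Going by the values given here, no step between two measured compounds that differ in one place is available, so nothing in the measured pairs speaks directly to the change now in question.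

Compound 3 `O=C(Nc1cccc(-n2cc(-c3ccncc3)c(-c3cc(O)cc(Cl)c3)n2)c1)Nc1ccc(Cl)c(Cl)c1` is not yet measured in this assay. It differs from compound 2 in one place: chloro in place of trifluoromethyl on an aromatic carbon. Cut one bond further out, the change reads 4-chloro-3-(trifluoromethyl)phenyl to 3,4-dichlorophenyl. The step is expected to be small, in either direction or none beyond the scatter, given that compound 2 already gives 2.08% and the alteration is confined to a single group. The estimated step from compound 2 to compound 3 is a number 5.9 percentage points higher from compound 2 to compound 3 (within the scatter). For compound 3 the estimate is 8%, with a range from 1% to 30%.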

Compound 3, a percentage reported as activity, at one concentration (the size of the read-out at that concentration, not a potency): -84.7%
The estimate for compound 3 lay 92.7 percentage points above the measured number; the whole stated range lies above it.
By their numbers in this assay, from the lowest: compound 3; then compound 2; then compound 1.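

In this assay, going by these compounds alone, the change from 4-chloro-3-(trifluoromethyl)phenyl to 3,4-dichlorophenyl gives the first one-place comparison in the urea series, and it gives a number 86.8 percentage points lower from compound 2 to compound 3 (beyond the scatter). Compound 2 at 2.08% had seemed to leave little room, yet compound 3 reaches -84.7%, a negative number, so this aromatic carbon ortho to a chloro group is a place where a single-group exchange moves the read-out strongly, and swapping trifluoromethyl for chloro is far from a neutral replacement here. The compounds shown offer no separate measurement that would explain the size of this step.

Open, going by these compounds, is whether chloro is particular at this place, or whether bromo, methyl, methoxy or a nitrile would read like chloro, like trifluoromethyl, or differently from both. Also open, on these data alone, is whether the same exchange carries the same weight outside this urea and hydroxy-substituted setting, since compound 1 differs from compound 2 and compound 3 in more than one place and cannot speak to it.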